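Halogens on the Phenyl Ring: Expecting Compound 4

This account rests on a few compounds, and the source may have more. Where it says the series, first, only, none or still open, it means among the compounds named here.

Measured compounds:
Compound 1 `CCCn1c(=O)[nH]c2nc(-c3ccc(S(=O)(=O)N4CCN(Cc5ccc(Br)cc5)CC4)cc3)[nH]c2c1=O` gives 28%
Compound 2 `CCCn1c(=O)[nH]c2nc(-c3ccc(S(=O)(=O)N4CCN(c5cccc(F)c5)CC4)cc3)[nH]c2c1=O` gives 44%
Compound 3 `CCCn1c(=O)[nH]c2nc(-c3ccc(S(=O)(=O)N4CCN(c5ccccc5)CC4)cc3)[nH]c2c1=O` gives 27%

In an assay on CHO cells for displacement of a labelled ligand from adenosine receptor A3 (Homo sapiens), read by scintillation counting, with a stated time of 45 min, tested at 1 uM, in the presence of a further agent that is not named here (a higher number here means more inhibition at the concentration tested (going by the name of the read-out), a lower number less inhibition), compound 3 stands lowest of the three numbers; compound 1 is its nearest neighbour, within the scatter, and compound 2 its furthest, with the step of a number 17 percentage points lower from compound 2 to compound 3 (beyond the scatter) lying beyond the scatter. Compound 4 `CCCn1c(=O)[nH]c2nc(-c3ccc(S(=O)(=O)N4CCN(c5ccc(Cl)cc5F)CC4)cc3)[nH]c2c1=O` is compound 3 with 4-chloro-2-fluorophenyl in place of phenyl on an amine nitrogen in a ring. Among the compounds with values here, the one measured step that bears on this is a number 17 percentage points lower from compound 2 to compound 3 (beyond the scatter), in which hydrogen replaced fluoro on the phenyl and the inhibition fell. Compound 4 goes the other way, bringing a fluoro and a chloro onto the phenyl, so a modest rise is expected, about a number 15 percentage points higher from compound 3 to compound 4 (beyond the scatter). Compound 4 is therefore estimated at 42%, with a likely range from 26% to 58%.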

Compound 4, a percentage reported as inhibition, at one concentration (the size of the read-out at that concentration, not a potency): 14%
Compound 4: the middle estimate sits 28 percentage points above what was measured, and the stated range ends above it.
By their numbers in this assay, from the lowest: compound 4; then compounds 3 and 1 (each within the scatter of the next); then compound 2.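

Halogens on this phenyl do not simply raise the number: 4-chloro-2-fluorophenyl in place of phenyl gives a number 13 percentage points lower from compound 3 to compound 4 (beyond the scatter) and so runs against the rise seen with the single fluoro of compound 2. The same group gives a number 30 percentage points lower from compound 2 to compound 4 (beyond the scatter) and a number 14 percentage points lower from compound 1 to compound 4 (beyond the scatter) and leaves compound 4 lowest of the four, so which halogens are present and where they sit matters here, not merely that they are present. Nothing measured here explains this result.

Compound 4 brings in both halogens at once, so the compounds shown leave open whether the chloro or the fluoro goes with the fall. Simple 4-chlorophenyl and 2-fluorophenyl groups would separate the two.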